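The source may hold more compounds than are shown below. What is called first, only, known or untested is meant among the compounds shown, and "the series" means these compounds.

Working notes on a series on a shared core. Compound 1 `CC1=C(/C=C/C(=O)/C=C/c2ccccc2C(F)(F)F)C(C)(C)CCC1O` gives 2900 nM in a functional assay on LNCaP cells (Homo sapiens) for cytotoxicity, read by MTT assay, with a stated time of 72 h; on this read-out higher numbers stand for weaker inhibition and lower numbers for stronger inhibition. Compound 2 `CC1=C(/C=C/C(=O)/C=C/c2cc(C(F)(F)F)ccc2C(F)(F)F)C(C)(C)CCC1O` gives 3200 nM in this assay; the change trifluoromethyl in place of hydrogen on an aromatic carbon produced a 1.1-fold higher number from compound 1 to compound 2 (0.04 log units; within the scatter). Compound 3 `CC1=C(/C=C/C(=O)/C=C/c2ccccc2F)C(C)(C)CCC1O` gives 2900 nM in this assay; its core differs from that of compound 1 by fluoro in place of trifluoromethyl on an aromatic carbon, with no change at the digits printed from compound 1 to compound 3 (within the scatter). Compound 4 `CC1=C(/C=C/C(=O)/C=C/c2ccc(C(F)(F)F)cc2F)C(C)(C)CCC1O` is still to be measured in this assay; it differs from compound 3 by trifluoromethyl in place of hydrogen on an aromatic carbon. This is the same kind of change as that made from compound 1 to compound 2, though in compound 4 the entering group sits meta to a fluoro group and para to a large group, whereas in compound 2 it sits meta to a large group and para to a trifluoromethyl group. Because a 1.1-fold higher number from compound 1 to compound 2 (0.04 log units; within the scatter) lay within the scatter, the expected step of a 1.1-fold higher number from compound 3 to compound 4 (0.03 log units; within the scatter) is likewise small. Compound 4 is estimated at 3100 nM, with a range from 1500 nM to 6500 nM.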

Compound 4, half-maximal inhibitory concentration: 2600 nM
The estimate for compound 4 lay 1.2-fold (0.08 log units) above the measured number; the measured number falls inside the stated range.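

In this assay, trifluoromethyl in place of hydrogen on an aromatic carbon produces a 1.1-fold lower number from compound 3 to compound 4 (0.05 log units; within the scatter). Set beside the earlier step, the change carries from one core to the other with no difference that can be read: the same change on two cores in this assay, a 1.1-fold higher number (0.04 log units; within the scatter) from compound 1 to compound 2 and a 1.1-fold lower number (0.05 log units; within the scatter) from compound 3 to compound 4, 1.2-fold (0.09 log units) apart, within the scatter of two such steps. This shows that the change moves the number little in both pairs, but with one pair per core and a different place in each, it does not show that the two places are equivalent or that the result extends to other cores.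

The compounds shown leave open whether an amine or a carboxylic acid on the aromatic ring, in place of fluoro or trifluoromethyl, would move the number beyond the scatter. They also leave open what replacing the hydroxyl group of the shared core would do.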